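The source may report more compounds than this note shows. Statements on the series, on what has been measured and on what is new or still open speak of the compounds shown alone.

Among three compounds built on one shared core, compound 1 `Cc1ccc(C2=NN(c3nc(-c4ccc([N+](=O)[O-])cc4)cs3)C(c3ccc(F)cc3)C2)s1` gives 16.7 ug/mL in a functional assay on A549 cells (Homo sapiens) for antiproliferative activity, read by XTT assay, with a stated time of 24 h; a lower number here means a stronger inhibitor, a higher number a weaker inhibitor. Compound 3 `COc1ccc(-c2csc(N3N=C(c4ccc(C)s4)CC3c3ccc(F)cc3)n2)cc1` gives 184 ug/mL in this assay, the higher of the two numbers shown. Compound 2 `Cc1ccc(C2=NN(c3nc(-c4ccc(C(F)(F)F)cc4)cs3)C(c3ccc(F)cc3)C2)s1` reaches only a limit of the assay, > 500 ug/mL in this assay. Compound 4 `Cc1ccc(C2=NN(c3nc(-c4ccc(Cl)cc4)cs3)C(c3ccc(F)cc3)C2)s1` differs from compound 3 by chloro in place of methoxy on an aromatic carbon. Within the data shown here, no measured step swaps methoxy for chloro. The steps that come closest are an 11-fold higher number from compound 1 to compound 3 (1.04 log units; beyond the scatter) and an at least 2.7-fold lower number from compound 2 to compound 3 (0.43 log units; beyond the scatter), and together with an at least 29-fold higher number from compound 1 to compound 2 (1.47 log units; beyond the scatter) they show that the group on this aromatic carbon moves the number over a wide span. Chloro is none of these three groups, so the step of a 1.2-fold lower number from compound 3 to compound 4 (0.09 log units; within the scatter) is expected to stay modest. Compound 4 is expected to give 150 ug/mL, somewhere between 30 ug/mL and 500 ug/mL.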

Compound 4, half-maximal inhibitory concentration: > 500 ug/mL
Compound 4 gave a limit, no number; the forecaster's own chance of this, stated with the estimate: 25%; middle value at least 3.3-fold (0.52 log units) away from the limit.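

The change from 4-methoxyphenyl to 4-chlorophenyl is not a small one in this assay, giving an at least 2.7-fold higher number from compound 3 to compound 4 (0.43 log units; beyond the scatter). Compound 1, with nitro at this position, now stands apart from a third group, with an at least 29-fold higher number from compound 1 to compound 4 (1.47 log units; beyond the scatter), and it has the lowest number of the four compounds. The step between compound 2 and compound 4 cannot be read, since both sit at a limit: the limit of > 500 ug/mL in this assay, at which 2 of the 4 values shown sit.

The compounds shown leave open whether nitro is alone in giving a low number at this position. An amine or a carboxylic acid in the same place could come close to compound 1 or stay far from it.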